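Halogen Swap on the Fused Ring of a Sulfonyl Series

The source may report more compounds than this note shows. Statements on the series, on what has been measured and on what is new or still open speak of the compounds shown alone.

Measured compounds:
Compound 1 `Cc1cc(C)cc(S(=O)(=O)c2cnc3cc(F)ccc3c2N2CCC(C)CC2)c1`: 80%
Compound 2 `CC1CCN(c2c(S(=O)(=O)c3ccc(Cl)c(Cl)c3)cnc3cc(F)ccc23)CC1`: 94%
Compound 3 `CC1CCN(c2c(S(=O)(=O)c3ccc(C#N)cc3)cnc3cc(Cl)ccc23)CC1`: 70%

Three compounds were tested in an assay on isolated protein for displacement of a labelled ligand from metabotropic glutamate receptor 5 (Homo sapiens), with a stated time of 60 min, tested at 1 uM; on this read-out lower numbers stand for less inhibition and higher numbers for more inhibition at the one concentration tested (going by the name of the read-out). Compound 1 gives 80% in this assay, and compound 2 gives 94%. Within the data shown here, the only step between two measured compounds that differ in one place is a number 14 percentage points higher from compound 1 to compound 2 (beyond the scatter), a change on the sulfonyl sulfur rather than on the shared core. Compound 3 gives 70% in this assay and stands at the low end of the three numbers; compound 1 lies within the usual scatter of it, while compound 2 lies beyond it.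

Compound 4 `CC1CCN(c2c(S(=O)(=O)c3ccc(C#N)cc3)cnc3cc(F)ccc23)CC1` has not yet been measured. It differs from compound 3 by fluoro in place of chloro on an aromatic carbon. Among the measured compounds shown here, no measured step addresses this exchange directly, since the one measured step concerns the group on the sulfonyl sulfur. Compound 1 and compound 2 carry the fluoro on the core and compound 3 carries the chloro, but their sulfonyl groups also differ, so those values settle nothing on their own. The expected change is therefore small, a number 5 percentage points higher from compound 3 to compound 4 (within the scatter), with no direction beyond the scatter. Compound 4 is estimated at 75%, between 55% and 90%.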

Compound 4, a percentage reported as inhibition, at one concentration (the size of the read-out at that concentration, not a potency): 83%
The estimate for compound 4 lay 8 percentage points below the measured number; the measured number falls inside the stated range.
By their numbers in this assay, from the lowest: compounds 3, 1 and 4 (each within the scatter of the next, the first and the last beyond it); then compound 2.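

Among these compounds, with 4-cyanophenyl held on the sulfonyl sulfur, fluoro in place of chloro on an aromatic carbon gives a number 13 percentage points higher from compound 3 to compound 4 (beyond the scatter) in this assay, the first reading of this exchange with nothing else changed. With fluoro held on the core, 4-cyanophenyl in place of 3,4-dichlorophenyl gives a number 11 percentage points lower from compound 2 to compound 4 (beyond the scatter) and 4-cyanophenyl in place of 3,5-dimethylphenyl gives a number 3 percentage points higher from compound 1 to compound 4 (within the scatter) so among these three sulfonyl groups only 3,4-dichlorophenyl stands apart. Nothing at hand accounts for the step between the two halogens.

The compounds shown leave open whether the exchange of chloro for fluoro gives a similar step with 3,4-dichlorophenyl or 3,5-dimethylphenyl on the sulfur. They also leave open what a bromo, a methoxy or an amine on this aromatic carbon would give.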